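Extending the amide tail of compound 2 with a chlorinated aryl group

The source may hold more compounds than are shown below. What is called first, only, known or untested is meant among the compounds shown, and "the series" means these compounds.

Compound 2 `CCN1CCN(CC(=O)Nc2ccc(-c3nc(-c4ccccc4)c(-c4ccccc4)n3C)cc2)CC1` and compound 1 `Cn1c(-c2ccc(NC(=O)CCl)cc2)nc(-c2ccccc2)c1-c1ccccc1` share one core and differ only at the end of the amide chain. In a functional assay on MCF7 cells (Homo sapiens) for cytotoxicity, read by MTT assay, with a stated time of 24 h, tested at 6.4 ug/mL (a higher number here means a stronger effect of the compound at the concentration tested, a lower number a weaker effect), compound 2 gives 16.4%, and compound 1 gives 14.2%; the step of a number 2.2 percentage points higher from compound 1 to compound 2 (within the scatter) is within the scatter, so neither stands apart. Compound 3 `Cn1c(-c2ccc(NC(=O)CN3CCN(Cc4ccc(Cl)cc4)CC3)cc2)nc(-c2ccccc2)c1-c1ccccc1` differs from compound 2 by 4-chlorophenyl in place of methyl on a saturated chain carbon bound to an amine nitrogen in a ring. Among the compounds with values here, no measured step touches this position, and the one step known at this tail was small. A step of a number 2.6 percentage points higher from compound 2 to compound 3 (within the scatter) is therefore expected, and compound 3 is estimated at 19%, between 8% and 36%.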

Compound 3, a percentage reported as activity, at one concentration (the size of the read-out at that concentration, not a potency): 33.4%
Estimate against measurement, compound 3: 14.4 percentage points below, within the range that was stated.
By their numbers in this assay, from the lowest: compounds 1 and 2 (each within the scatter of the next); then compound 3.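

Within the data shown here, replacing methyl with 4-chlorophenyl on a saturated chain carbon bound to an amine nitrogen in a ring gives a number 17 percentage points higher from compound 2 to compound 3 (beyond the scatter) in this assay and is the first change to go beyond the scatter. The earlier change at this tail gave a number 2.2 percentage points higher from compound 1 to compound 2 (within the scatter) and so showed no clear effect, whereas this position does respond to at least one group. Nothing available explains the rise.

Going by these compounds, whether the gain comes from the added aromatic ring or from its chlorine remains open. Plain benzyl, 4-fluorobenzyl or a longer chain ending in 4-chlorophenyl could help separate these possibilities.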